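Mirror-Image Change on a Urea: Compound 2 to Compound 3

The source may hold more compounds than are shown below. What is called first, only, known or untested is meant among the compounds shown, and "the series" means these compounds.

Two ureas have so far been measured in an ADME assay on the whole organism with Oryza sativa as the target, tested at 0.1 uM; a higher number here means a weaker effect of the compound at the concentration tested, a lower number a stronger effect. Compound 1, with the structure `CCc1cccc(NC(=O)N[C@@H](C)c2ccccc2)c1`, gives 100%. Compound 2, with the structure `C[C@@H](NC(=O)Nc1cccc(C(F)(F)F)c1)c1ccccc1`, gives 82%. Of these two numbers, compound 2 holds the lower one, and the nearest value, that of compound 1, lies higher by a gap beyond the usual scatter of this measurement.

Compound 3, with the structure `C[C@H](NC(=O)Nc1cccc(C(F)(F)F)c1)c1ccccc1`, has not yet been measured. (the two compounds have the same atoms and bonds and differ only in configuration as drawn: 1 of 1 stereo elements differ; a stereocentre at a saturated chain carbon is drawn R in compound 2 and S in compound 3). For the measured compounds named here, no measured pair here shows what such a change in configuration does in this assay, so there is nothing to lean on for the size of the step, and such a change can leave the number where it is or move it either way. The step from compound 2 to compound 3 is expected to be a number 6 percentage points higher from compound 2 to compound 3 (within the scatter), which is small and within the scatter. Compound 3 is therefore estimated to give about 88%, with a range from 65% to 100%.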

Compound 3, a percentage reported as activity, at one concentration (the size of the read-out at that concentration, not a potency): 94%
For compound 3 the middle estimate is 6 percentage points below the measured one; the range from low to high includes it.
By their numbers in this assay, from the lowest: compound 2; then compounds 3 and 1 (each within the scatter of the next).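

In this assay, a change of configuration alone gives a number 12 percentage points higher from compound 2 to compound 3 (beyond the scatter), so the handedness of this stereocentre can move the number by more than the usual scatter. The shift can be traced to the stereocentre and to nothing else in the structure, as one fact makes clear: the fact that compounds 2 and 3 differ only in the configuration as drawn. The other new comparison concerns the aromatic group rather than the stereocentre: trifluoromethyl in place of ethyl on an aromatic carbon gives a number 6 percentage points lower from compound 1 to compound 3 (within the scatter), so this pair shows no clear effect of that swap.

The compounds shown leave open whether the same mirror-image change gives a step of similar size and direction when ethyl, a nitrile or a chlorine atom stands in place of trifluoromethyl. They also leave open how an amine or a carboxylic acid on the shared core would affect the number.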